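Methoxy for Nitro on the Ring at the Aromatic Nitrogen

A few compounds are considered here, and "the series" means these few. Any claim that something is new, unique, unknown or untested is made for them only; others in the source may bear on it.

Measured compounds:
compound 1 `COc1cc2c(Oc3ccc(NC(=O)c4nn(-c5ccccc5Br)c(=O)c5ccccc45)cc3F)ccnc2cc1OCCCN1CCCC1` — 320 nM
compound 2 `COc1cc2c(Oc3ccc(NC(=O)c4nn(-c5ccc([N+](=O)[O-])cc5)c(=O)c5ccccc45)cc3F)ccnc2cc1OCCCN1CCCC1` — 1240 nM

In a functional assay on NCI-H460 cells (Homo sapiens) for cytotoxicity, read by MTT assay, with a stated time of 72 h (a lower number here means a stronger inhibitor, a higher number a weaker inhibitor), compound 2 gives 1240 nM, the higher of the two numbers, while compound 1 gives 320 nM. Compound 3 `COc1ccc(-n2nc(C(=O)Nc3ccc(Oc4ccnc5cc(OCCCN6CCCC6)c(OC)cc45)c(F)c3)c3ccccc3c2=O)cc1` differs from compound 2 by methoxy in place of nitro on an aromatic carbon. Among the compounds with values here, no measured step covers this exact change; the single step at hand, a 3.9-fold higher number from compound 1 to compound 2 (0.59 log units; beyond the scatter), shows only that altering the ring on the aromatic nitrogen shifts the number modestly. For compound 3 a modest step toward a lower number is therefore expected, a 1.8-fold lower number from compound 2 to compound 3 (0.25 log units; within the scatter), with wide uncertainty. Compound 3 is estimated at 700 nM, between 250 nM and 2000 nM.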

Compound 3, half-maximal inhibitory concentration: 1650 nM
Compound 3: the middle estimate sits 2.4-fold (0.37 log units) below what was measured; the measured number falls inside the stated range.
By their numbers in this assay, from the lowest: compound 1; then compounds 2 and 3 (each within the scatter of the next).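

In this assay, methoxy in place of nitro on the aromatic carbon para to a large group gives a 1.3-fold higher number from compound 2 to compound 3 (0.12 log units; within the scatter), so this exchange does not separate the two compounds. Set against the 2-bromophenyl ring of compound 1, the 4-methoxyphenyl ring gives a 5.2-fold higher number from compound 1 to compound 3 (0.71 log units; beyond the scatter), so compound 1 stands apart from both 4-substituted rings. Nothing available explains these numbers. The compounds shown leave open whether an amine or a carboxylic acid on that carbon would read differently from nitro and methoxy. They also leave open whether the number for compound 1 belongs to the bromine itself or to its place on the ring.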